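This account rests on a few compounds, and the source may have more. Where it says the series, first, only, none or still open, it means among the compounds named here.

For the measured compounds named here, compound 2 `COc1cccc(CNCCCNc2ccnc3cc(-c4ccccc4)ccc23)c1O` stands at the higher end of the two compounds measured so far. In a physicochemical assay for solubility, with a stated time of 18 h, at pH 7.4 (on this read-out higher numbers stand for higher solubility and lower numbers for lower solubility), compound 2 gives 32000 nM. Going by the values given here, its nearest neighbour is compound 1 `COc1cccc(CNCCCNc2ccnc3cc(Cc4ccc(C#N)cc4)ccc23)c1O`, which in this assay gives 4200 nM; the single measured step between them is a 7.6-fold higher number from compound 1 to compound 2 (0.88 log units; beyond the scatter). Compound 3 `COc1ccccc1Oc1ccc2c(NCCCNCc3cccc(OC)c3O)ccnc2c1` differs from compound 2 at the very same place: 2-methoxyphenoxy in place of phenyl on an aromatic carbon. Among the compounds with values here, the only step that bears on this change is the one from compound 1 to compound 2, which also exchanged the group at this position and was modest in size. That step shows that swapping this group can shift the number, but it does not indicate which way the 2-methoxyphenoxy would move it. A change of similar or smaller size, in no certain direction, is therefore expected. Compound 3 is expected to give about 35000 nM in this assay, within a range from 9000 nM to 130000 nM, which amounts to an expected step of a 1.1-fold higher number from compound 2 to compound 3 (0.04 log units; within the scatter).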

Compound 3, solubility: 14500 nM
For compound 3 the middle estimate is 2.4-fold (0.38 log units) above the measured one; measured number inside the range.
By their numbers in this assay, from the lowest: compound 1; then compound 3; then compound 2.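

In this assay, putting 2-methoxyphenoxy in place of phenyl gives a 2.2-fold lower number from compound 2 to compound 3 (0.34 log units; beyond the scatter) and so shows that this exchange moves the number downward, which compound 1 and compound 2 alone could not tell. Set against the 4-cyanobenzyl group, the same 2-methoxyphenoxy group gives a 3.5-fold higher number from compound 1 to compound 3 (0.54 log units; beyond the scatter) and so falls between the other two groups, with all three compounds separated by steps beyond the scatter. Nothing at hand explains why these three groups give different numbers.

On these data alone, it remains open whether the drop from phenyl comes from the linking oxygen or from the methoxy group, a question that plain phenoxy at this position could help to settle. As far as these compounds go, how an amine or a carboxylic acid would read here also remains open.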